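This account rests on a few compounds, and the source may have more. Where it says the series, first, only, none or still open, it means among the compounds named here.

Measured in a functional assay on A549 cells (Homo sapiens) for cytotoxicity, read by MTT assay, with a stated time of 72 h; a lower number here means a stronger inhibitor, a higher number a weaker inhibitor:
- Compound 1 `COc1ccccc1/C=C1\CCC/C(=C\c2cccc(OC)c2OC)C1=O`: > 20000 nM
- Compound 2 `COc1ccc(/C=C2\CCC/C(=C\c3cccc(OC)c3OC)C2=O)cc1`: > 20000 nM
- Compound 3 `COc1cccc(/C=C2\CCC/C(=C\c3cccc(Cl)c3Cl)C2=O)c1OC`: > 20000 nM

Each of these three entries is a limit of the assay and not a number.

In this assay compound 2 has only a limit, > 20000 nM. The next compound, compound 4 `COc1ccc(/C=C2\CCC/C(=C\c3cccc(OC)c3OC)C2=O)c(OC)c1`, has not yet been measured. It differs from compound 2 by methoxy in place of hydrogen on an aromatic carbon. That ring in compound 4 holds the methoxy groups found singly in compound 1 and compound 2.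

The nearest evidence is a step that the two limits leave unreadable from compound 1 to compound 2, which compares those two single placements. Two further steps change that ring more widely: a step that the two limits leave unreadable from compound 1 to compound 3 and a step that the two limits leave unreadable from compound 2 to compound 3. None of the three has a readable size because of the limit of > 20000 nM in this assay, at which 3 of the 3 values shown sit. They therefore offer no measured size for the added methoxy, and no direction for it either. No step beyond the scatter is expected in this assay, and compound 4 is expected to remain weak, most likely reported only as a limit. The expected change is a step that the limit leaves unreadable from compound 2 to compound 4. For compound 4 the estimated value is 25000 nM, with an expected range from 8000 nM to 60000 nM.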

Compound 4, half-maximal inhibitory concentration: > 20000 nM
Compound 4 ended at the assay's limit; the forecaster's own chance of this, stated with the estimate: 70%; the middle value lies beyond the limit too.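

Neither the comparison of compound 4 with compound 2 nor its comparison with compound 1 gives a readable step, because each of these compounds has a limit of the assay and not a number: the limit of > 20000 nM in this assay, at which 4 of the 4 values shown sit.

The compounds shown leave open what size or direction the added methoxy has in this assay, and whether any substitution of these rings gives a measurable value there.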